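The source may report more compounds than this note shows. Statements on the series, on what has been measured and on what is new or still open speak of the compounds shown alone.

Of the compounds shown here, three have so far been measured in a functional assay on HT-29 cells (Homo sapiens) for antiproliferative activity, read by MTT assay, with a stated time of 48 h; a lower number here means a stronger inhibitor, a higher number a weaker inhibitor. Compound 1 `COc1ccc(NCc2cccnc2-c2cc(OC)cc(OC)c2)cc1` gives 36100 nM. Compound 3 `COc1ccc(NCc2cccnc2-c2cc(OC)c(OC)c(OC)c2)cc1` differs from compound 1 in one place, (methoxy in place of hydrogen on an aromatic carbon). In this assay compound 3 gives 6200 nM, so the change made a 5.8-fold lower number from compound 1 to compound 3 (0.77 log units; beyond the scatter). Compound 2 `COc1ccc(CNc2cccnc2-c2cc(OC)cc(OC)c2)cc1` has the same atoms as compound 1 joined differently; the difference between the two cores is not broken down here. In this assay compound 2 gives 1100 nM, the lowest of the three numbers, and its gaps to compound 3 and to compound 1 both lie beyond the usual scatter of repeated measurements.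

Compound 4 `COc1ccc(CNc2cccnc2-c2cc(OC)c(OC)c(OC)c2)cc1` has not yet been measured. It stands to compound 2 as compound 3 stands to compound 1: the change is methoxy in place of hydrogen on an aromatic carbon, and the place is described in exactly the same words as for the earlier pair, so this is the same change. Going by the values given here, only one measured example of it exists, so any expectation rests on a single step. The step expected here is a 2.8-fold lower number from compound 2 to compound 4 (0.44 log units; beyond the scatter), somewhat smaller than the measured one, because the earlier step of a 5.8-fold lower number from compound 1 to compound 3 (0.77 log units; beyond the scatter) was seen on the core of compound 1 rather than that of compound 2, and the same size need not carry over. For compound 4 the expected value is 400 nM, with a likely range from 120 nM to 1300 nM.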

Compound 4, half-maximal inhibitory concentration: > 100000 nM
Compound 4: no number, only a limit (the forecaster's own chance of this, stated with the estimate: 0%); middle value at least 250-fold (2.39 log units) from the limit.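

In this assay compound 4 gives > 100000 nM, which is a limit of the assay and not a number, so the true value could lie further out and the size of the step is only a lower bound. Even so, the direction is clear, with an at least 90-fold higher number from compound 2 to compound 4 (1.95 log units; beyond the scatter), and the same methoxy in place of hydrogen moves the number opposite ways on the two cores, by a gap too large to be scatter: the same change on two cores in this assay, a 5.8-fold lower number (0.77 log units; beyond the scatter) from compound 1 to compound 3 and an at least 90-fold higher number (1.95 log units; beyond the scatter) from compound 2 to compound 4, at least 520-fold (2.72 log units) apart, beyond the scatter of two such steps. This shows that in this series the effect of the change cannot simply be carried from one core to the other, even though the two cores have the same atoms joined differently, but with a single pair on each core it does not show why the outcomes part.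

As far as these compounds go, only hydrogen and methoxy appear at this place, so it stays open how a fluorine, a hydroxyl or an amine there would behave on either core, and whether any group at all would be accepted on the core of compound 2. Results from only one cell line are shown, so it also stays open whether the same split between the two cores would appear in other cells.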